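Fluoro for Chloro on the Aryl Ring of Compound 1

A few compounds are considered here, and "the series" means these few. Any claim that something is new, unique, unknown or untested is made for them only; others in the source may bear on it.

Measured compounds:
compound 1, `CCC(C(=O)N1CCN(c2ccccc2Cl)CC1)N1C(=O)CCC1=O`, 50%
compound 2, `CC(C(=O)N1CCN(c2ccc(F)cc2)CC1)N1C(=O)CCC1=O`, 25%

The study turns on a functional assay on the whole organism (strain Swiss) with Mus musculus as the target, in the maximal electroshock model, with a stated time of 1 h, at a dose of 300 mg/kg by the intraperitoneal route; on this read-out higher numbers stand for a stronger effect at the one dose given and lower numbers for a weaker effect. Compound 1 gives 50% in this assay, the higher of the two numbers recorded; compound 2 gives 25%, a gap that lies beyond the scatter of the method. Within the data shown here, compound 2 differs from compound 1 in more than one place, so nothing can be said about which of its changes accounts for the lower number, only that the two values stand apart.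

The unmeasured compound 3, `CCC(C(=O)N1CCN(c2ccccc2F)CC1)N1C(=O)CCC1=O`, is the closer relative of compound 1. Among the measured compounds shown here, the single change is fluoro in place of chloro on an aromatic carbon. For the measured compounds named here, the ethyl chain and the shared core of compound 1 are kept, so compound 3 is the first pair in this set to isolate one halogen swap.

Going by the values given here, no step between measured compounds covers this change. Compound 3 is therefore expected to land somewhat below compound 1, with a step of a number 10 percentage points lower from compound 1 to compound 3 (within the scatter) that may well stay within the scatter. The estimate for compound 3 in this assay is 40%, with a range from 15% to 65%.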

Compound 3, a percentage reported as activity, at one dose (the size of the read-out at that dose, not a potency): 50%
Estimate against measurement, compound 3: 10 percentage points below; the range from low to high includes it.
By their numbers in this assay, from the lowest: compound 2; then compounds 1 and 3 (each within the scatter of the next).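

In this assay, putting fluoro in place of chloro on an aromatic carbon, ortho to a large group, gives no change at the digits printed from compound 1 to compound 3 (within the scatter). Among these compounds, this is the first change in the set that can be read at one place, and it shows that, at the one dose given, the read-out does not separate 2-chlorophenyl from 2-fluorophenyl with the ethyl chain and the shared core held constant. No measurement shown here offers an explanation for this result.

As far as these compounds go, the pair covers only these two halogens at this one place, so it remains open whether a bromo group, a methoxy group or plain hydrogen there would keep the number of compound 1 or move it beyond the scatter. Among the compounds shown here, compound 2 differs from both compound 1 and compound 3 in more than one place, so no step to it can be read, and the effect of moving a halogen around the aromatic ring, or of a longer chain in place of the ethyl chain, also stays open.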